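Chlorobenzyl triazole thioethers on the shared core: a note

The source may hold more compounds than are shown below. What is called first, only, known or untested is meant among the compounds shown, and "the series" means these compounds.

The series is measured in a functional assay on ECa-109 cells (Homo sapiens) for inhibition, read by MTT assay, with a stated time of 72 h; on this read-out higher numbers stand for weaker inhibition and lower numbers for stronger inhibition. Compound 1 `N#Cc1c(Nc2ccc(Cl)cc2)nc(SCc2cn(Cc3ccccc3Cl)nn2)nc1-c1ccccc1` gives 1420 nM. Compound 2 `Cc1ccc(Nc2nc(SCc3cn(Cc4ccc(Cl)cc4)nn3)nc(-c3ccccc3)c2C#N)cc1`, with a 4-methylphenyl on the anilino nitrogen and a 4-chlorobenzyl on the triazole, is recorded only as a limit of the assay, > 64000 nM, and so its standing among the numbers is known only from the limit of > 64000 nM in this assay, at which 1 of the 2 values shown sits: it sits at the upper edge of what this assay reports, with no number beneath it. Among the compounds with values here, compound 1 and compound 2 differ in more than one place, so their two values show only that one is a number and the other a limit.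

The next compound is compound 3 `Cc1ccc(Nc2nc(SCc3cn(Cc4ccccc4Cl)nn3)nc(-c3ccccc3)c2C#N)cc1`, which differs from compound 2 in that (2-chlorophenyl in place of 4-chlorophenyl on a saturated chain carbon bound to an aromatic nitrogen). Within the data shown here, no step between two measured compounds covers this change, so its size in this assay is not established. A move toward stronger inhibition is nevertheless expected, because compound 1 carrying the same 2-chlorobenzyl gives 1420 nM. The expected step of an at least 4.2-fold lower number from compound 2 to compound 3 (0.63 log units; beyond the scatter) is therefore set in that direction, though with wide uncertainty since compound 2 is only a limit. Compound 3 is estimated at 15000 nM, within a range from 3000 nM to 64000 nM.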

Compound 3, half-maximal inhibitory concentration: > 64000 nM
Compound 3 was reported as a limit; the forecaster's own chance of this, stated with the estimate: 35%; at least 4.2-fold (0.63 log units) between middle value and limit.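

In this assay the 2-chlorobenzyl does not by itself give a measurable value: compound 3 carries that group and is recorded only as a limit of the assay, > 64000 nM. Within the data shown here, with the 2-chlorobenzyl held fixed, methyl in place of chloro on an aromatic carbon gives an at least 45-fold higher number from compound 1 to compound 3 (1.65 log units; beyond the scatter), the first step that can be read, and it marks this aromatic carbon as a place where one change separates a measured value from a limit. The change from 4-chlorobenzyl to 2-chlorobenzyl itself cannot be read, since compound 2 and compound 3 are both limits and no size can be drawn from them: the limit of > 64000 nM in this assay, at which 2 of the 3 values shown sit.

As far as these compounds go, whether the chloro is specifically required on that aromatic carbon stays open, and a fluoro, a methoxy or a plain hydrogen there would test this against the methyl. From the compounds shown here alone, it is also open what the 4-chlorobenzyl or an unsubstituted benzyl gives when chloro sits on that aromatic carbon, and only such a pair could show whether the benzyl substitution matters at all.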